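This account rests on a few compounds, and the source may have more. Where it says the series, first, only, none or still open, it means among the compounds named here.

Measured so far:
Compound 1 `CC(=O)Oc1ccccc1C1CC(C)=NN1C(=O)CN(C(C)C)C(C)C`: 20100 nM
Compound 2 `O=C(c1ccccc1)N1N=C(c2cc3ccccc3oc2=O)CC1c1ccccc1`: 12700 nM

Both numbers come from a functional assay on MGC-803 cells (Homo sapiens) for cytotoxicity, read by MTT assay, with a stated time of 48 h; a higher number here means a weaker inhibitor, a lower number a stronger inhibitor. Compound 2 has the lower of the two numbers, but compound 1 lies within the scatter of it, so the two cannot be told apart on this evidence.

Compound 3 `CC(C)(C)NCC(=O)N1N=C(c2cc3ccccc3oc2=O)CC1c1ccccc1` has not yet been measured. It keeps the core of compound 2 and differs in one place: ((tert-butyl)amino)methyl in place of phenyl on a carbonyl carbon. The group that leaves is a ring with no hydrogen-bond donor or acceptor; the group that enters is a chain carrying one of each. Compound 1, whose acyl group also ends in an amine, gives 20100 nM, and that lies within the scatter of the value of compound 2.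

For the measured compounds named here, no step between measured compounds is known, so the expectation rests on that comparison alone. In this assay a change from compound 2 to compound 3 of no more than the scatter, in either direction, is expected. Compound 3 is therefore estimated to give about 15000 nM, with a range from 5000 nM to 45000 nM. This estimate means a step of a 1.2-fold higher number from compound 2 to compound 3 (0.07 log units; within the scatter), expected to stay within the scatter.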

Compound 3, half-maximal inhibitory concentration: 15400 nM
The estimate for compound 3 lay 1.0-fold (0.01 log units) below the measured number, within the range that was stated.
By their numbers in this assay, from the lowest: compounds 2, 3 and 1 (each within the scatter of the next).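

Replacing the phenyl on a carbonyl carbon with ((tert-butyl)amino)methyl gives a step of a 1.2-fold higher number from compound 2 to compound 3 (0.08 log units; within the scatter) in this assay and so leaves compound 2 and compound 3 indistinguishable. For the compounds shown here, this is the first direct reading at this position, where the shared core stays fixed and only one group is exchanged: an aromatic ring without hydrogen-bond donors or acceptors gives way to an open chain that has them, and the measured effect is no larger than the scatter. No measurement shown here offers an explanation for this result.

A single exchange cannot show whether this position tolerates change in general, or whether other groups on the same carbonyl carbon, such as a morpholine ring, a carboxylic acid or a longer chain ending in an amine, would produce a step beyond the scatter. As far as these compounds go, it also remains open whether a smaller amine such as dimethylamino, or a fluorine atom on the phenyl ring of compound 2, would move the number in this assay at all.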